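Adding one methoxy to the benzyl group of compound 1

The source may hold more compounds than are shown below. What is called first, only, known or untested is meant among the compounds shown, and "the series" means these compounds.

compound 1 `COc1ccc(CN(C(=O)CSC(=S)N2CCN(C(=O)OC(C)(C)C)CC2)c2cc(OC)c(OC)c(OC)c2)cc1` gives 310 nM in a functional assay on MGC-803 cells (Homo sapiens) for inhibition, read by CCK-8 assay, with a stated time of 48 h; a higher number here means a weaker inhibitor, a lower number a stronger inhibitor
compound 2 `COc1ccc(CN(C(=O)CSC(=S)N2CCN(C(=O)OC(C)(C)C)CC2)c2ccccc2)cc1` gives > 20000 nM in this assay as a limit of the assay

Within the data shown here, compound 1 holds the only true number so far, so it has no measured neighbour to rank against. Compound 3 `COc1ccc(CN(C(=O)CSC(=S)N2CCN(C(=O)OC(C)(C)C)CC2)c2cc(OC)c(OC)c(OC)c2)cc1OC` keeps the core of compound 1 and carries one change, (methoxy in place of hydrogen on an aromatic carbon), which turns 4-methoxybenzyl into 3,4-dimethoxybenzyl. Among the measured compounds shown here, the only measured step, an at least 64-fold higher number from compound 1 to compound 2 (1.80 log units; beyond the scatter), took place on a different aryl group and rests on the limit of > 20000 nM in this assay, at which 1 of the 2 values shown sits, and its true size stays open. It shows that this series can respond steeply to methoxy groups, but it does not measure a change at the benzyl group. A moderate loss in this assay is therefore expected, though a result within the scatter remains possible. The estimate is a 1.6-fold higher number from compound 1 to compound 3 (0.21 log units; within the scatter) and this size is only an expectation. For compound 3 the expected value is 500 nM with an estimated range from 100 nM to 3000 nM.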

Compound 3, half-maximal inhibitory concentration: > 20000 nM
Compound 3: only a limit was reported; the forecaster's own chance of this, stated with the estimate: 5%; at least 40-fold (1.60 log units) between middle value and limit.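

In this assay, among these compounds, the added methoxy gives an at least 64-fold higher number from compound 1 to compound 3 (1.80 log units; beyond the scatter), so a change at the benzyl group, and not only one at the aryl group on the amide-type nitrogen, can carry the result beyond the scatter. Compound 3 gives > 20000 nM, which is a limit of the assay. The full size of this step therefore cannot be read: the limit of > 20000 nM in this assay, at which 2 of the 3 values shown sit.

The compounds shown leave open whether this loss belongs to methoxy itself or would also follow from another group at this place, such as a fluorine, a hydroxyl or an amine. They also leave open whether a longer chain such as ethoxy in place of the added methoxy would give a measurable number rather than a limit.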